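Three methoxy groups on the benzoate: a cytotoxicity estimate

A few compounds are considered here, and "the series" means these few. Any claim that something is new, unique, unknown or untested is made for them only; others in the source may bear on it.

Measured compounds:
- compound 1 `COC(=O)/C(=C\c1ccc(OC(=O)c2ccccc2)cc1)Sc1ccnc2cc(Cl)ccc12`: 30200 nM
- compound 2 `COC(=O)/C(=C\c1ccc(OC(=O)c2ccccc2OC)cc1)Sc1ccnc2cc(Cl)ccc12`: 44500 nM
- compound 3 `COC(=O)/C(=C\c1ccc(OC(=O)c2ccc(OC)cc2OC)cc1)Sc1ccnc2cc(Cl)ccc12`: 7640 nM

The three compounds share one core and differ only in the aryl group attached to the carbonyl carbon of the ester. In a functional assay on HL-60 cells (Homo sapiens) for cytotoxicity, read by MTT assay, with a stated time of 24 h (on this read-out lower numbers stand for stronger inhibition and higher numbers for weaker inhibition), compound 1 gives 30200 nM, the second highest of the three numbers. Its nearest neighbour is compound 2, with a 1.5-fold higher number from compound 1 to compound 2 (0.17 log units; within the scatter); the furthest is compound 3, with a 4.0-fold lower number from compound 1 to compound 3 (0.60 log units; beyond the scatter). Compound 2 to compound 3 shows a 5.8-fold lower number from compound 2 to compound 3 (0.77 log units; beyond the scatter).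

Compound 4 `COC(=O)/C(=C\c1ccc(OC(=O)c2cc(OC)cc(OC)c2OC)cc1)Sc1ccnc2cc(Cl)ccc12` has not been measured. It differs from compound 1 by 2,3,5-trimethoxyphenyl in place of phenyl on a carbonyl carbon.

Going by the values given here, the step that bears most directly on this change is the one from compound 1 to compound 3, where a dimethoxyphenyl in place of phenyl gave a modest drop in the number. Among the compounds with values here, the single methoxy of compound 2 produced nothing beyond the scatter. Adding a third methoxy, in a new arrangement, leaves the outcome uncertain, but a modest downward step in this assay is the most reasonable expectation, roughly a 2.5-fold lower number from compound 1 to compound 4 (0.40 log units; beyond the scatter).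

Compound 4 is therefore estimated at 12000 nM, with a range from 4000 nM to 40000 nM.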

Compound 4, half-maximal inhibitory concentration: 10700 nM
The estimate for compound 4 lay 1.1-fold (0.05 log units) above the measured number, within the range that was stated.
By their numbers in this assay, from the lowest: compounds 3 and 4 (each within the scatter of the next); then compounds 1 and 2 (each within the scatter of the next).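

In this assay the 2,3,5-trimethoxyphenyl group gives a 2.8-fold lower number from compound 1 to compound 4 (0.45 log units; beyond the scatter) and also a 4.2-fold lower number from compound 2 to compound 4 (0.62 log units; beyond the scatter), so a second aryl group with several methoxy groups now sits apart from both phenyl and 2-methoxyphenyl on this carbonyl carbon. Until now only the 2,4-dimethoxyphenyl group of compound 3 had shown such a separation, and compound 2 remains the case that goes against any simple rule that each added methoxy lowers the number, since its step from compound 1 stays within the scatter. The result against compound 3 is a 1.4-fold higher number from compound 3 to compound 4 (0.15 log units; within the scatter), so going from 2,4-dimethoxyphenyl to 2,3,5-trimethoxyphenyl gives no difference that this read-out can separate, even though the entering group is larger by one methoxy.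

All the aryl groups shown carry only methoxy groups or hydrogen, so it remains open whether a hydroxyl group, a chlorine atom or an amine on the aryl group would give a similar number, or whether a saturated carbon chain could stand in place of the aryl group altogether. No measurement at hand offers a reason for any of these steps.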